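The compounds below may be only part of what the source reports. "The series", "measured", "known", "first", "only" and "open" are said of these compounds alone.

Measured so far in a functional assay on HL-60 cells (Homo sapiens) for cytotoxicity, read by MTT assay, with a stated time of 72 h; a lower number here means a stronger inhibitor, a higher number a weaker inhibitor:
Compound 1 `O=S(=O)(c1ccc(Br)cc1)c1nc2ccccc2nc1N1CCCC1`: 6070 nM
Compound 2 `O=S(=O)(c1ccc(Br)cc1)c1nc2ccccc2nc1N1CCc2ccccc2C1`: 2610 nM
Compound 3 `Cc1ccc(S(=O)(=O)c2nc3ccccc3nc2N2CCCC(O)C2)cc1`: 6080 nM

Compound 3 gives 6080 nM, level with compound 1 within the scatter, while compound 2 gives the lower 2610 nM. Compound 4 `O=S(=O)(c1ccc(Br)cc1)c1nc2ccccc2nc1N1CCCC(O)C1` is compound 3 with a single change: bromo in place of methyl on an aromatic carbon, para to a large group. Going by the values given here, no measured step isolates this change. Among the compounds with values here, the one measured step, a 2.3-fold lower number from compound 1 to compound 2 (0.37 log units; beyond the scatter), is modest and concerns a different group, 1,2,3,4-tetrahydroisoquinolin-2-yl in place of pyrrolidin-1-yl, so it bears on the change only indirectly. The closest evidence is a comparison of two values: compound 1, with the 4-bromophenyl group, gives 6070 nM, and compound 3, with the 4-methylphenyl group, gives 6080 nM, although these two also differ in a second place. A step beyond the scatter is therefore not expected in this assay. The expected result is a 1.1-fold lower number from compound 3 to compound 4 (0.04 log units; within the scatter). For compound 4 the estimated value is 5500 nM, with an expected range of 2600 nM to 11000 nM.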

Compound 4, half-maximal inhibitory concentration: 3430 nM
The estimate for compound 4 lay 1.6-fold (0.21 log units) above the measured number, within the range that was stated.
By their numbers in this assay, from the lowest: compounds 2, 4, 1 and 3 (each within the scatter of the next, the first and the last beyond it).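

In this assay, the change from 4-methylphenyl to 4-bromophenyl can now be read directly, and it gives a 1.8-fold lower number from compound 3 to compound 4 (0.25 log units; within the scatter), so bromo in place of methyl at this position does not separate the pair. With the 4-bromophenyl group kept, 3-hydroxypiperidin-1-yl in place of pyrrolidin-1-yl gives a 1.8-fold lower number from compound 1 to compound 4 (0.25 log units; within the scatter), and in place of 1,2,3,4-tetrahydroisoquinolin-2-yl it gives a 1.3-fold higher number from compound 2 to compound 4 (0.12 log units; within the scatter), so compound 4 stands within the scatter of both, although these two lie beyond the scatter of each other. Nothing available gives a reason for these readings.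

The compounds shown leave open whether bromo in place of methyl reads the same alongside pyrrolidin-1-yl or 1,2,3,4-tetrahydroisoquinolin-2-yl. They also leave open whether a methoxy group, an amine or a carboxylic acid at this position would give a step beyond the scatter.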